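The compounds below may be only part of what the source reports. "The series", "measured", "known", "first", "only" and "open" are said of these compounds alone.

Working notes on the series, measured so far:
- compound 1 `O=C(/C=C/c1ccc([N+](=O)[O-])cc1)Nc1cc2c(Nc3ccc(F)c(Cl)c3)ncnc2cc1O[C@H]1CCOC1` gives 26700 nM
- compound 2 `N#Cc1ccc(/C=C/C(=O)Nc2cc3c(Nc4ccc(F)c(Cl)c4)ncnc3cc2O[C@H]2CCOC2)cc1` gives 9830 nM
- compound 3 `COc1ccc(/C=C/C(=O)Nc2cc3c(Nc4ccc(F)c(Cl)c4)ncnc3cc2O[C@H]2CCOC2)c(OC)c1OC` gives 4650 nM

In a functional assay on MCF7 cells (Homo sapiens) for cytotoxicity, read by MTT assay, with a stated time of 72 h (on this read-out lower numbers stand for stronger inhibition and higher numbers for weaker inhibition), compound 3 stands lowest of the three at 4650 nM and compound 2 is its nearest neighbour. The next compound to consider is compound 4 `COc1cc(/C=C/C(=O)Nc2cc3c(Nc4ccc(F)c(Cl)c4)ncnc3cc2O[C@H]2CCOC2)cc(OC)c1`. The change is 3,5-dimethoxyphenyl in place of 2,3,4-trimethoxyphenyl on a double-bonded chain carbon bound to a double-bonded chain carbon.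

Three measured steps replace this same aromatic group: a 2.7-fold lower number from compound 1 to compound 2 (0.43 log units; beyond the scatter) and a 2.1-fold lower number from compound 2 to compound 3 (0.33 log units; beyond the scatter) and a 5.7-fold lower number from compound 1 to compound 3 (0.76 log units; beyond the scatter). All three are modest, although each lies beyond the scatter. None of them compares two methoxy-bearing groups, so the data give no direct guide to direction.

The widest of these steps, a 5.7-fold lower number from compound 1 to compound 3 (0.76 log units; beyond the scatter), spans two quite different groups, whereas the change at hand keeps methoxy groups on the ring. A smaller step than that one is therefore expected in this assay, with no clear direction. The estimated step is a 1.3-fold higher number from compound 3 to compound 4 (0.11 log units; within the scatter), and no step beyond the scatter is expected.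

For compound 4 the estimated value is 6000 nM, with an expected range from 2500 nM to 15000 nM.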

Compound 4, half-maximal inhibitory concentration: 30300 nM
Estimate against measurement, compound 4: 5.1-fold (0.70 log units) below; measured number outside the range, above it.
By their numbers in this assay, from the lowest: compound 3; then compound 2; then compounds 1 and 4 (each within the scatter of the next).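

In this assay, two methoxy-bearing aryl groups are not interchangeable at this place: 3,5-dimethoxyphenyl in place of 2,3,4-trimethoxyphenyl on a double-bonded chain carbon bound to a double-bonded chain carbon gives a 6.5-fold higher number from compound 3 to compound 4 (0.81 log units; beyond the scatter), so methoxy groups on the ring do not by themselves set the number. Set against the 4-cyanophenyl group, the 3,5-dimethoxyphenyl group gives a 3.1-fold higher number from compound 2 to compound 4 (0.49 log units; beyond the scatter), and set against the 4-nitrophenyl group it gives a 1.1-fold higher number from compound 1 to compound 4 (0.05 log units; within the scatter), which leaves that pair level. The methoxy-bearing groups therefore occupy both ends of the series, with the 2,3,4-trimethoxyphenyl group at the lowest number and the 3,5-dimethoxyphenyl group level with the 4-nitrophenyl group at the high end.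

No measurement at hand accounts for these steps. Compound 3 and compound 4 differ in both the number and the placement of their methoxy groups, so the two remain unseparated, and a 3,4,5-trimethoxyphenyl or a 4-methoxyphenyl group would be needed to pull them apart, while a 4-aminophenyl group or a carboxylic acid on the ring remains an open comparison.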